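Swapping a Ring-Nitrogen Substituent and Expected Cell Tolerance

The compounds below may be only part of what the source reports. "The series", "measured", "known", "first", "only" and "open" are said of these compounds alone.

Cytotoxicity in liver-derived cells was followed with an ADME assay on HepG2 2.2.15 cells (Homo sapiens) for cytotoxicity; a higher number here means that more compound is tolerated, a lower number that less compound is tolerated. Compound 1, `O=C(Nc1ncc(Cc2ccc(Br)cc2)s1)c1ccc2ccccc2c1`, was tolerated across the whole tested range. In this assay compound 1 gives > 50000 nM, which is a limit of the measurement and not a number. Compound 2, `Clc1ccc(C(Oc2ccc3cc(Br)ccc3c2)c2cnc(NCC3CCCCC3)s2)cc1`, shares part of its core with compound 1 but carries different groups around it. In this assay compound 2 is recorded as "not toxic" (no number reported), with no number given, so it stands among the tolerated compounds but cannot be placed on a numerical scale against compound 1. Compound 3, `O=C(Nc1ncc(C(Oc2ccc3cc(Br)ccc3c2)c2ccc(Cl)cc2)s1)c1ccc(F)cc1`, has not yet been measured. It differs from compound 2 in one place: (4-fluorophenyl)carbonyl in place of cyclohexylmethyl on a nitrogen on an aromatic ring. Through this change compound 3 comes to resemble compound 1 in the group carried on the ring nitrogen, and compound 1 sits at the limit (the limit of > 50000 nM in this assay, at which 1 of the 2 values shown sits). For the measured compounds named here, no measured step covers this change, so its size cannot be read from the data; the expectation is no shift beyond the scatter, with compound 3 remaining tolerated. Compound 3 is therefore estimated at 50000 nM in this assay, within 20000 nM to 100000 nM, and most likely reported again only as a limit.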

Compound 3, half-maximal cytotoxic concentration: "not toxic" (no number reported)
Compound 3 has no reported number here, and the estimate cannot be compared.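

For the compounds shown here, compound 2 and compound 3 are both recorded in this assay as not toxic, with no number, so no step between them can be read. The only figure shown is a limit, and it belongs to compound 1: the limit of > 50000 nM in this assay, at which 1 of the 3 values shown sits. Going by these compounds, whether (4-fluorophenyl)carbonyl in place of cyclohexylmethyl changes cell tolerance at all stays open.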